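The compounds below may be only part of what the source reports. "The series", "measured", "known", "first", "only" and "open" are said of these compounds alone.

Of the compounds shown here, three have been measured in a physicochemical assay for acid dissociation. Compound 1 `c1ccc(Oc2ccc3c(NCCCNCc4ccco4)ccnc3c2)cc1` gives 9.28. Compound 2 `COc1cccc(CNCCCNc2ccnc3cc(Oc4ccc(Cl)cc4)ccc23)c1O` gives 9.28, and compound 3 `COc1ccc(F)cc1CNCCCNc1ccnc2cc(CCC(C)C)ccc12` gives 9.47. Compound 2 stands level with compound 1 at the digits shown, and together they are the lowest of the three numbers; its nearest neighbour is compound 1, with no change at the digits shown, and its furthest is compound 3, whose number lies higher by an amount that still falls within the scatter. In other words, all three values sit close together, and no one of them can be called higher or lower than another with confidence.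

The next compound to be measured in this assay is compound 4 `COc1cccc(Oc2ccc3c(NCCCNCc4cccc(OC)c4O)ccnc3c2)c1`. It differs from compound 2 in one place: 3-methoxyphenyl in place of 4-chlorophenyl on an oxygen on an aromatic ring. Among the measured compounds shown here, no measured pair in this set differs in exactly one place, so there is no directly comparable step to lean on. Given that compounds 1, 2 and 3, which differ from each other at several places, all give values within the scatter of one another, the expectation for this change is a step of no size beyond the scatter, in no particular direction, a number 0.02 log units higher from compound 2 to compound 4 (within the scatter). Compound 4 is therefore estimated to give 9.3, expected to lie between 9 and 9.6.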

Compound 4, acid dissociation constant: 9.28
Estimate against measurement, compound 4: 0.02 log units above; the range from low to high includes it.
By their numbers in this assay, from the lowest: compounds 1, 2, 4 and 3 (each within the scatter of the next).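

Swapping 4-chlorophenoxy for 3-methoxyphenoxy gives the first comparison in this set between compounds that differ in only one place, and in this assay the step reads no change at the digits printed from compound 2 to compound 4 (within the scatter). At this position, on an oxygen on an aromatic ring, a chlorine-bearing ring can therefore give way to a methoxy-bearing ring, which adds a hydrogen-bond acceptor and a heavy atom, while the two compounds remain indistinguishable in this assay. No measurement offered here explains this result, so the comparison records what was seen but not the reason for it.

Among the compounds shown here, this single step covers only two uncharged aryl groups at one position, so it remains open whether a ring carrying an amine or a carboxylic acid, or a plain alkyl chain on the same oxygen, would also leave the reading indistinguishable. The other parts of the structure have no single-place comparison among these compounds, so the effect of a longer chain linking the two nitrogens, or of a different ring at the far end of that chain, also remains unknown.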